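Swapping methoxy for hydroxyamino on a fused aromatic ring

The source may hold more compounds than are shown below. What is called first, only, known or untested is meant among the compounds shown, and "the series" means these compounds.

Of the compounds shown here, three sharing one core have been measured in an assay on cells for inhibition of ileal sodium/bile acid cotransporter (Homo sapiens); on this read-out higher numbers stand for weaker inhibition and lower numbers for stronger inhibition. Compound 1 `CCCC[C@]1(CC)CS(=O)(=O)c2ccc(-c3ccccc3)cc2[C@@H](c2cccc(OC)c2)[C@H]1O` gives 180 nM. Compound 2 `CCCC[C@]1(CC)CS(=O)(=O)c2ccc(OC)cc2[C@@H](c2ccccc2)[C@H]1O` gives 55 nM, a number beyond the scatter below that of compound 1, while compound 3 `CCCC[C@]1(CC)CS(=O)(=O)c2cc(O)ccc2[C@@H](c2ccccc2)[C@H]1O` gives 90 nM, a number within the scatter of compound 2. Compound 4 `CCCC[C@]1(CC)CS(=O)(=O)c2ccc(NO)cc2[C@@H](c2ccccc2)[C@H]1O` has not yet been measured in this assay; it differs from compound 2 by hydroxyamino in place of methoxy on an aromatic carbon. No measured pair isolates this change, so any expectation rests only on the three numbers shown. A modest weakening, not clearly beyond the scatter, is expected for the step of a 1.6-fold higher number from compound 2 to compound 4 (0.21 log units; within the scatter). Compound 4 is therefore estimated at 90 nM, with a likely range from 35 nM to 250 nM.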

Compound 4, half-maximal inhibitory concentration: 260 nM
Compound 4: middle estimate off by 2.9-fold (0.46 log units), on the low side; the measured number lies above the stated range.
By their numbers in this assay, from the lowest: compounds 2, 3, 1 and 4 (each within the scatter of the next, the first and the last beyond it).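

In this assay, among the compounds shown here, hydroxyamino in place of methoxy on this aromatic carbon gives a 4.7-fold higher number from compound 2 to compound 4 (0.67 log units; beyond the scatter), the first step in this set that isolates a single change. For the compounds shown here, it shows that this position does not treat the two groups alike, something the earlier compounds, which differ in more than one place, could not show. No available evidence explains the difference. Still open, going by these compounds, is how an amine or a carboxylic acid on this same carbon would compare with methoxy and hydroxyamino.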